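This account rests on a few compounds, and the source may have more. Where it says the series, first, only, none or still open, it means among the compounds named here.

In an ADME assay on cells (Hepatocyte, Homo sapiens) for metabolic stability, with a stated time of 30 min (a higher number here means that more of the compound is left, a lower number that less of the compound is left), three compounds sharing one core have been measured: compound 1 `CC(=O)OC1CCC(CN2CCN(c3cc(=O)c4cc(C(F)(F)F)cc([N+](=O)[O-])c4s3)CC2)CC1` gives 0%, compound 2 `O=C(OC1CCC(CN2CCN(c3cc(=O)c4cc(C(F)(F)F)cc([N+](=O)[O-])c4s3)CC2)CC1)C1CCCCC1` gives 2.8%, and compound 3 `O=C(OC1CCC(CN2CCN(c3cc(=O)c4cc(C(F)(F)F)cc([N+](=O)[O-])c4s3)CC2)CC1)c1ccc(F)cc1` gives 3%. Compound 3 therefore stands within the scatter of both other compounds, and very little of any of the three is left. Compound 4 `O=C(OC1CCC(CN2CCN(c3cc(=O)c4cc(C(F)(F)F)cc([N+](=O)[O-])c4s3)CC2)CC1)c1cccs1` differs from compound 3 at the same place where these three differ: thiophen-2-yl in place of 4-fluorophenyl on a carbonyl carbon. Among the compounds with values here, no thiophen-2-yl compound has been measured yet, so the evidence comes only from the three measured steps at this place. These are a number 2.8 percentage points higher from compound 1 to compound 2 (within the scatter), a number 3 percentage points higher from compound 1 to compound 3 (within the scatter) and a number 0.2 percentage points higher from compound 2 to compound 3 (within the scatter). All three are small and stay within the scatter, across methyl, cyclohexyl and 4-fluorophenyl. No step beyond the scatter is therefore expected in this assay, and the expected step is no change at the digits printed from compound 3 to compound 4 (within the scatter). For compound 4 the estimated value is 3%, with an expected range from 0% to 10%.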

Compound 4, percent of the compound remaining: 2.2%
For compound 4 the middle estimate is 0.8 percentage points above the measured one; low and high end bracket the measured number.
By their numbers in this assay, from the lowest: compounds 1, 4, 2 and 3 (each within the scatter of the next).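

In this assay, putting thiophen-2-yl on the carbonyl carbon gives a number 0.8 percentage points lower from compound 3 to compound 4 (within the scatter), a number 0.6 percentage points lower from compound 2 to compound 4 (within the scatter) and a number 2.2 percentage points higher from compound 1 to compound 4 (within the scatter). A five-membered aromatic ring with one hetero atom thus joins methyl, cyclohexyl and 4-fluorophenyl at this place without any step beyond the scatter, and the hydrogen-bond acceptor that enters with thiophen-2-yl brings none either. Nothing available explains why so little of any of the four compounds is left or why this place makes so little difference.

Going by these compounds, it remains open whether a group of another kind on this carbonyl carbon, such as an amine or a carboxylic acid, would leave more of the compound. On these data alone, it is equally open whether an amide in place of the ester, or a change elsewhere on the shared core, would do so.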